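The source may report more compounds than this note shows. Statements on the series, on what has been measured and on what is new or still open speak of the compounds shown alone.

Three compounds share one core and differ in the aryl group on the amide-type nitrogen: compound 1 (`Cc1cc(NC(=O)Nc2ccccc2N)c2ccccc2n1`), compound 2 (`Cc1cc(NC(=O)Nc2ccc(F)cc2)c2ccccc2n1`) and compound 3 (`Cc1cc(NC(=O)Nc2ccc(O)cc2)c2ccccc2n1`). In an ADME assay for permeability, using PAMPA, at pH 7.4 (on this read-out lower numbers stand for lower permeability and higher numbers for higher permeability), compound 1 gives 300 10^-6 cm/s, the second highest of the three numbers, with compound 2 at 801 10^-6 cm/s and compound 3 at 3 10^-6 cm/s.

Compound 4 (`Cc1cc(NC(=O)Nc2ccccc2C(F)(F)F)c2ccccc2n1`) has not yet been measured in this assay. It differs from compound 1 by trifluoromethyl in place of amino on an aromatic carbon, ortho to a large group.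

Among the compounds with values here, no measured step makes this exact exchange. The nearest is a 2.7-fold higher number from compound 1 to compound 2 (0.43 log units; beyond the scatter), a modest rise in which the 2-aminophenyl also leaves, though 4-fluorophenyl is only a loose match for the new group. Within the data shown here, the large falls, a 100-fold lower number from compound 1 to compound 3 (2.00 log units; beyond the scatter) and a 270-fold lower number from compound 2 to compound 3 (2.43 log units; beyond the scatter), both end at compound 3, the only compound with a hydroxy group, and compound 4 has none.

A modest rise in this assay is therefore expected, similar in direction and size to the step to compound 2. The expected change is a 2.3-fold higher number from compound 1 to compound 4 (0.37 log units; beyond the scatter). For compound 4 the estimate is 700 10^-6 cm/s, with an expected range of 250 10^-6 cm/s to 1600 10^-6 cm/s.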

Compound 4, apparent permeability: 945 10^-6 cm/s
Estimate against measurement, compound 4: 1.4-fold (0.13 log units) below, and the stated range covers the measured number.
By their numbers in this assay, from the lowest: compound 3; then compound 1; then compounds 2 and 4 (each within the scatter of the next).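

In this assay, within the data shown here, the exchange at this one place, on an aromatic carbon ortho to a large group, gives a 3.2-fold higher number from compound 1 to compound 4 (0.50 log units; beyond the scatter) and is the only step that keeps a substituent here while changing just that substituent. It shows that the number stays high when amino, with 1 hydrogen-bond donor, gives way to trifluoromethyl, with 0 hydrogen-bond donors and 4 heavy atoms, so the level of compound 2 is not confined to its 4-fluorophenyl group: compound 2 and compound 4 lie within the scatter of each other. The data in hand offer no measurement that bears on why the number rises, and the step stands as an observation only.

Open, from the compounds shown here alone, is how a nitrile, a methoxy group or a carboxylic acid at this same place would read in this assay and whether the trend from amino to trifluoromethyl would hold for them. Also open, going by these compounds, is whether hydroxy at this place would bring a fall of the size of a 270-fold lower number from compound 2 to compound 3 (2.43 log units; beyond the scatter) or whether that fall belongs to its place in compound 3.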